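A Triazole Attachment Swap Judged From Its Neighbours

The source may report more compounds than this note shows. Statements on the series, on what has been measured and on what is new or still open speak of the compounds shown alone.

Compound 1 `Cc1cc(C)c(NC(=O)N(Cc2ccc(-c3ccsc3)cc2)C2CCCCCC2)c(C)c1` gives 19 nM in an assay on microsomes from intestine for inhibition of acyl-CoA:cholesterol acyltransferase (Oryctolagus cuniculus); on this read-out lower numbers stand for stronger inhibition and higher numbers for weaker inhibition.
Compound 2 `Cc1cc(C)c(NC(=O)N(Cc2ccc(-n3cccn3)cc2)C2CCCCCC2)c(C)c1` gives 70 nM in this assay.
Compound 3 `Cc1cc(C)c(NC(=O)N(Cc2ccc(-n3ccnn3)cc2)C2CCCCCC2)c(C)c1` gives 42 nM in this assay.

Compound 3 stands second highest of the three numbers; its step from compound 1 reads a 2.2-fold higher number from compound 1 to compound 3 (0.34 log units; beyond the scatter), while the step from compound 2 reads a 1.7-fold lower number from compound 2 to compound 3 (0.22 log units; within the scatter). Compound 4 `Cc1cc(C)c(NC(=O)N(Cc2ccc(-n3nccn3)cc2)C2CCCCCC2)c(C)c1` carries the change (2H-1,2,3-triazol-2-yl in place of 1H-1,2,3-triazol-1-yl on an aromatic carbon). For the measured compounds named here, no measured step swaps one triazole attachment for the other; the nearest guide is the exchange of azoles in a 1.7-fold lower number from compound 2 to compound 3 (0.22 log units; within the scatter), which stayed within the scatter, and the shift from thiophen-3-yl in a 3.7-fold higher number from compound 1 to compound 2 (0.57 log units; beyond the scatter), which was modest. The step from compound 3 to compound 4 is therefore expected to be a 1.1-fold higher number from compound 3 to compound 4 (0.03 log units; within the scatter), not beyond the scatter. Compound 4 is estimated at 45 nM, between 20 nM and 100 nM.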

Compound 4, half-maximal inhibitory concentration: 130 nM
Beside the measured number, compound 4's estimate is 2.9-fold (0.46 log units) below it, and the stated range ends below it.
By their numbers in this assay, from the lowest: compound 1; then compounds 3, 2 and 4 (each within the scatter of the next, the first and the last beyond it).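

Joining the same triazole through a different nitrogen is enough on its own to move the read-out in this assay: 2H-1,2,3-triazol-2-yl in place of 1H-1,2,3-triazol-1-yl gives a 3.1-fold higher number from compound 3 to compound 4 (0.49 log units; beyond the scatter), so at this position the attachment matters and not only the atoms present. The exchange for 1H-pyrazol-1-yl gives a 1.9-fold higher number from compound 2 to compound 4 (0.27 log units; within the scatter). Thiophen-3-yl gives way to the same triazole with a 6.8-fold higher number from compound 1 to compound 4 (0.84 log units; beyond the scatter), the largest step seen at this position.

Nothing available explains the gap between the two triazole attachments. From the compounds shown here alone, whether an imidazol-1-yl or a 2H-tetrazol-2-yl group at this place would follow either triazole remains open.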